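The source may hold more compounds than are shown below. What is called first, only, known or untested is meant among the compounds shown, and "the series" means these compounds.

Measured compounds in the series:

- compound 1, `CCN(Cc1ccccc1)Cc1ccc(CN2CCc3ccc(OS(N)(=O)=O)cc3C2)cc1`: 1%
- compound 2, `NS(=O)(=O)Oc1ccc2c(c1)CN(C(=O)c1cccc(N(Cc3ccccc3)Cc3ccco3)c1)CC2`: 27.5%
- compound 3, `CCN(Cc1ccc(Br)cc1)c1ccc(C(=O)N2CCc3ccc(OS(N)(=O)=O)cc3C2)cc1`: 78.2%

All three share the same core and were tested in an assay on HEK293 cells for inhibition of Steryl-sulfatase (Homo sapiens), tested at 0.1 uM; on this read-out lower numbers stand for a weaker effect and higher numbers for a stronger effect at the one concentration tested. Compound 2 stands second highest of the three numbers. Its nearest neighbour is compound 1, which gives 1%, a gap beyond the scatter; compound 3, which gives 78.2%, lies furthest from it, also beyond the scatter.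

Compound 4, `CN(C)CCN(Cc1ccccc1)c1cccc(C(=O)N2CCc3ccc(OS(N)(=O)=O)cc3C2)c1`, is not yet measured in this assay. It differs from compound 2 in one place:

(dimethylamino)methyl in place of furan-2-yl on a saturated chain carbon bound to a nitrogen on an aromatic ring

Going by the values given here, no step between measured compounds matches this change, so the expectation rests on compound 2 alone. A moderate step in this assay, downward or none beyond the scatter, is expected, given that compound 2 gives 27.5%. For compound 4 the expected value in this assay is 20%, with a range from 3% to 45%. The step this estimate means is a number 7.5 percentage points lower from compound 2 to compound 4 (within the scatter).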

Compound 4, a percentage reported as inhibition, at one concentration (the size of the read-out at that concentration, not a potency): 0%
Beside the measured number, compound 4's estimate is 20 percentage points above it; the whole stated range lies above it.
By their numbers in this assay, from the lowest: compounds 4 and 1 (each within the scatter of the next); then compound 2; then compound 3.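

The position on a saturated chain carbon bound to a nitrogen on an aromatic ring does not accept every exchange in this assay: (dimethylamino)methyl in place of furan-2-yl gives a number 27.5 percentage points lower from compound 2 to compound 4 (beyond the scatter). The exchange removes a five-membered aromatic ring and brings in a group with no ring, while hydrogen-bond donors, hydrogen-bond acceptors and net charge count the same on both sides, so those counts do not separate the two groups. No measurement at hand bears on why the number falls.

Going by these compounds, whether the fall goes with the loss of the ring or with the entry of the amine stays open; a tetrahydrofuran-2-yl ring or a methoxymethyl group at this place would separate the two. Also open, on these data alone, is how a longer chain ending in the dimethylamino group would read.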